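Compound 2 Gains a Chloro Group on the Hydroxyphenyl Ring

The source may hold more compounds than are shown below. What is called first, only, known or untested is meant among the compounds shown, and "the series" means these compounds.

compound 1 `O=C(CBr)N1N=C(c2ccc(F)cc2)CC1c1ccccc1O`: 6000 nM
compound 2 `O=C(CN1CCCCC1)N1N=C(c2ccc(F)cc2)CC1c1ccccc1O`: 8020 nM

Of the compounds shown here, two with a shared core have been measured. In an assay on isolated protein for inhibition of Amine oxidase [flavin-containing] A (Homo sapiens), read by fluorescence, with stated times of 15 min and 20 min (on this read-out higher numbers stand for weaker inhibition and lower numbers for stronger inhibition), compound 1 gives 6000 nM, and in the same assay compound 2 gives 8020 nM. Going by the values given here, the only measured step is a 1.3-fold higher number from compound 1 to compound 2 (0.13 log units; within the scatter), a change that sits on the chain attached to the carbonyl. Compound 2 therefore stands at the highest of the two numbers, with compound 1 its nearest neighbour, and the gap between them falls within the scatter.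

Compound 3 `O=C(CN1CCCCC1)N1N=C(c2ccc(F)cc2)CC1c1cc(Cl)ccc1O` differs from compound 2 by chloro in place of hydrogen on an aromatic carbon. Among the compounds with values here, no measured step touches the 2-hydroxyphenyl ring, so the measured data offer no guide to the direction or size of this change. With nothing to point either way, the step from compound 2 to compound 3 is expected to be a 1.0-fold lower number from compound 2 to compound 3 (0.00 log units; within the scatter), that is, no step beyond the scatter. For compound 3 the estimate in this assay is 8000 nM, with a range from 3000 nM to 22000 nM.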

Compound 3, half-maximal inhibitory concentration: 3720 nM
For compound 3 the middle estimate is 2.2-fold (0.33 log units) above the measured one; the measured number falls inside the stated range.
By their numbers in this assay, from the lowest: compounds 3, 1 and 2 (each within the scatter of the next, the first and the last beyond it).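

In this assay, going by these compounds alone, chloro in place of hydrogen on an aromatic carbon gives a 2.2-fold lower number from compound 2 to compound 3 (0.33 log units; beyond the scatter) and so a modest step beyond the scatter, whereas the only earlier step, on the chain attached to the carbonyl, stayed within it. Within the data shown here, this is the first sign that the number responds to a change at this carbon, para to a hydroxy group and meta to a large group, at least with the piperidin-1-yl chain in place. No supporting information on why the chloro compound gives the lower number is available.

The compounds shown leave open whether the step depends on chloro itself, since fluoro, methyl, methoxy or a carboxylic acid at the same carbon would separate the effect of this group from that of any substitution there. They also leave open whether the same change would give a similar step with the bromo chain of compound 1 in place of the piperidin-1-yl chain, or at the other carbons of the hydroxyphenyl ring.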